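From Benzyl to tert-Butyl in a Series Without Readable Activity

This account rests on a few compounds, and the source may have more. Where it says the series, first, only, none or still open, it means among the compounds named here.

Compound 2 `COc1ccc(-n2cc(/C=[N+](\[O-])Cc3ccccc3)nn2)cc1` is tested in a functional assay on A549 cells (Homo sapiens) for inhibition, read by MTT assay, with a stated time of 24 h; a higher number here means a weaker inhibitor, a lower number a stronger inhibitor. In this assay compound 2 reaches only a limit, > 100000 nM. Its two neighbours sit the same way. Compound 1 `[O-]/[N+](=C\c1cn(-c2ccc(F)cc2)nn1)Cc1ccccc1` reaches only a limit in this assay, > 100000 nM. Compound 3 `[O-]/[N+](=C\c1cn(-c2ccc(C(F)(F)F)cc2)nn1)Cc1ccccc1` likewise reaches only a limit in this assay, > 100000 nM. The steps among them, a step that the two limits leave unreadable from compound 1 to compound 2, a step that the two limits leave unreadable from compound 1 to compound 3 and a step that the two limits leave unreadable from compound 2 to compound 3, cannot be read since all three sit at the limit of > 100000 nM in this assay, at which 3 of the 3 values shown sit. Compound 4 `COc1ccc(-n2cc(/C=[N+](\[O-])C(C)(C)C)nn2)cc1` differs from compound 2 by tert-butyl in place of benzyl on a double-bonded nitrogen. For the measured compounds named here, no measured step touches this position. For compound 4 the expected step is therefore a number no higher from compound 2 to compound 4 (the limit leaves the size open). Compound 4 is expected at 100000 nM, with a range from 30000 nM to 300000 nM, most likely again only a limit.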

Compound 4, half-maximal inhibitory concentration: 23700 nM
The estimate for compound 4 lay 4.2-fold (0.63 log units) above the measured number, outside the stated range (below it).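

In this assay, tert-butyl in place of benzyl on a double-bonded nitrogen gives an at least 4.2-fold lower number from compound 2 to compound 4 (0.62 log units; beyond the scatter), so this position can shift the number, while the steps among compound 1, compound 2 and compound 3 cannot be read. The true size of the new step stays open because compound 2 reaches only a limit: the limit of > 100000 nM in this assay, at which 3 of the 4 values shown sit.

Still open, going by these compounds, is whether an isopropyl or cyclohexyl group on that nitrogen would also lower the number. Also open, on these data alone, is whether fluoro or trifluoromethyl in place of methoxy would change the number for compound 4.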